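Core Substituent Swap in a Diamine Series: Acid Dissociation

A few compounds are considered here, and "the series" means these few. Any claim that something is new, unique, unknown or untested is made for them only; others in the source may bear on it.

Compound 1 `COc1ccc(F)cc1CNCCCNc1ccnc2cc(C3CCCCC3)ccc12` is the reference point. In a physicochemical assay for acid dissociation, compound 1 gives 9.47. Compound 2 `c1coc(CNCCCNc2ccnc3cc(C4CCCCC4)ccc23)c1` gives 9.47 in this assay and compound 3 `COc1cccc(CNCCCNc2ccnc3cc(-c4ccc(C(C)(C)C)cc4)ccc23)c1O` gives 9.47, so compound 1 stands level with both at the digits read, the three values falling within the scatter of one another.

One measured step exists between neighbours: no change at the digits printed from compound 1 to compound 2 (within the scatter), a swap on a saturated chain carbon bound to an amine nitrogen that left the read-out flat. For compound 1 against compound 3 only the two values themselves can be spoken of, and they match.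

Compound 4 `COc1ccc(F)cc1CNCCCNc1ccnc2cc(Oc3ccc(Cl)cc3)ccc12` is not yet measured. It differs from compound 1 as follows: 4-chlorophenoxy in place of cyclohexyl on an aromatic carbon. For the measured compounds named here, this change sits on the fused two-ring core, away from the chain carrying the amine nitrogens, and no measured step touches that position. Going by the values given here, the single step in hand moved nothing beyond the scatter, and nothing among the measured compounds points to a shift from a core substituent. The step is therefore expected to be a number 0.07 log units lower from compound 1 to compound 4 (within the scatter), none beyond the scatter. For compound 4 the estimate in this assay is 9.4, with a range from 9 to 9.8.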

Compound 4, acid dissociation constant: 9.28
Compound 4: middle estimate off by 0.12 log units, on the high side, and the stated range covers the measured number.
By their numbers in this assay, from the lowest: compounds 4, 1, 2 and 3 (each within the scatter of the next).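

The position on the aromatic carbon of the shared core now has a measured step of its own: in this assay, 4-chlorophenoxy in place of cyclohexyl gives a number 0.19 log units lower from compound 1 to compound 4 (within the scatter) and so stays inside the usual spread of the assay. For the compounds shown here, a six-membered non-aromatic ring of carbon only can therefore give way at this position to a larger, oxygen-linked six-membered aromatic ring without the read-out leaving the scatter, as already seen for the single chain-side swap. Nothing available bears on why the read-out stays there.

This rests on one pair of compounds with one entering group, so a carboxylic acid or an amine on this same aromatic carbon remains an open case. Also open, from the compounds shown here alone, is whether 4-chlorophenoxy gives the same result with furan-2-yl on the chain, as in compound 2, in place of 5-fluoro-2-methoxyphenyl.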